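The compounds below may be only part of what the source reports. "The series", "measured", "known", "first", "only" and "open" are said of these compounds alone.

Measured so far in a functional assay on Jurkat cells (Homo sapiens) (on this read-out lower numbers stand for stronger inhibition and higher numbers for weaker inhibition), are these compounds:
- compound 1 `CC(C)[C@H](NC(=O)COc1cccc2ccccc12)C(=O)N[C@@H](CC(=O)O)C(=O)COc1ccc(-c2ccccc2)cc1` gives 87900 nM
- compound 2 `CC(C)[C@H](NC(=O)COc1cccc2ccccc12)C(=O)N[C@@H](CC(=O)O)C(=O)COc1ccc(Oc2ccccc2)cc1` gives 12700 nM
- compound 3 `CC(C)[C@H](NC(=O)COc1cccc2ccccc12)C(=O)N[C@@H](CC(=O)O)C(=O)COc1ccc(Oc2ccc(C(F)(F)F)cc2)cc1` gives 9300 nM

Compound 1 has the highest number of the three, so it is the weakest inhibitor here. Compound 4 `CC(=O)Nc1cccc(OCC(=O)[C@H](CC(=O)O)NC(=O)[C@@H](NC(=O)COc2cccc3ccccc23)C(C)C)c1` has 3-acetamidophenyl in place of 4-phenylphenyl on an oxygen on a saturated carbon. The nearest evidence comes from changes at the same end of the molecule. These are a 6.9-fold lower number from compound 1 to compound 2 (0.84 log units; beyond the scatter) and a 9.5-fold lower number from compound 1 to compound 3 (0.98 log units; beyond the scatter), both toward lower numbers. The further change, a 1.4-fold lower number from compound 2 to compound 3 (0.14 log units; within the scatter), adds little. None of these compounds carries an acetamido group or has a single ring at this end, so the measured steps guide only the direction, and loosely. Within the data shown here, a modest move toward stronger inhibition is therefore expected, no larger than the steps to compound 2 and compound 3. The expected change is a 2.9-fold lower number from compound 1 to compound 4 (0.47 log units; beyond the scatter), and it remains uncertain. For compound 4 the estimate is 30000 nM, with an expected range from 7000 nM to 120000 nM.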

Compound 4, half-maximal inhibitory concentration: > 100000 nM
Compound 4: no number, only a limit (the forecaster's own chance of this, stated with the estimate: 15%); middle value at least 3.3-fold (0.52 log units) from the limit.
By their numbers in this assay, from the lowest: compounds 3 and 2 (each within the scatter of the next); then compound 1. At a limit, above all of these: compound 4.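

In this assay compound 4 gives > 100000 nM, which is a limit of the assay and not a number. The step reads an at least 1.1-fold higher number from compound 1 to compound 4 (0.05 log units; that floor lies within the scatter), so it is only a floor: it does not establish that compound 4 is weaker than compound 1, but it does exclude the drop in number seen with compound 2 and compound 3. This position therefore does not give lower numbers with every replacement, and a single ring carrying an acetamido group brought no measurable gain over 4-phenylphenyl.

Since the second ring left and the acetamido group entered in one change, the compounds shown do not separate the two. From the compounds shown here alone, a plain phenyl, or a single ring carrying an amine or a carboxylic acid instead of the acetamido group, remains open.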